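Acetyl to hydrogen in a small cytotoxic series

This account rests on a few compounds, and the source may have more. Where it says the series, first, only, none or still open, it means among the compounds named here.

Measured in a functional assay on A2780 cells (Homo sapiens) for cytotoxicity; on this read-out higher numbers stand for weaker inhibition and lower numbers for stronger inhibition:
- compound 1 `Oc1cc(O)cc(CCCCCCCCC/C=C\CCCCCCCCCc2cc(O)cc(O)c2)c1` gives 10.2 ug/mL
- compound 2 `COc1cc(O)cc(CCCCCCC/C=C\CCCCCCCc2cc(O)cc(OC)c2)c1` gives 9.8 ug/mL
- compound 3 `CC(=O)Oc1cc(O)cc(CCCCCCC/C=C\CCCCCCCc2cc(O)cc(OC(C)=O)c2)c1` gives 9.4 ug/mL

The three numbers form a single tight group. Compound 3 at 9.4 ug/mL lies within the scatter of both compound 1 and compound 2, so no order can be read among them.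

The next compound to be tested is compound 4 `CC(=O)Oc1cc(O)cc(CCCCCCC/C=C\CCCCCCCc2cc(O)cc(O)c2)c1`. It arises from compound 3 by one change, (hydrogen in place of acetyl on an oxygen on an aromatic ring). In words, this is hydrogen in place of acetyl on an oxygen on an aromatic ring, or acetoxy to hydroxy, which turns the 3-acetoxy-5-hydroxyphenyl end into a 3,5-dihydroxyphenyl end.

Among the measured compounds shown here, no measured pair isolates this change, so there is no direct precedent for its size. For the measured compounds named here, the only guide is the narrow spread of the three values, and on that basis no step beyond the scatter is expected in this assay, in either direction. The estimated change is a 1.0-fold higher number from compound 3 to compound 4 (0.00 log units; within the scatter), which is expected to stay within the scatter. For compound 4 the expected value is 9.5 ug/mL, with an estimated range of 5.5 ug/mL to 16 ug/mL.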

Compound 4, half-maximal inhibitory concentration: 10.2 ug/mL
For compound 4 the middle estimate is 1.1-fold (0.03 log units) below the measured one; low and high end bracket the measured number.
By their numbers in this assay, from the lowest: compounds 3, 2, 1 and 4 (each within the scatter of the next).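

In this assay the series now holds its first pair that differs in one place: acetoxy to hydroxy, on an oxygen on an aromatic ring, gives a 1.1-fold higher number from compound 3 to compound 4 (0.04 log units; within the scatter). At this position, the 3-acetoxy-5-hydroxyphenyl end and the 3,5-dihydroxyphenyl end are therefore not told apart by this read-out, at least while the other end of the molecule keeps its acetoxy group. No independent data bear on why the step is this small.

Still open, from the compounds shown here alone, is whether the same position would stay within the scatter with a group of another kind on the ring in place of this oxygen substituent, such as an amine or a carboxylic acid, or whether the flat read-out holds only for acetoxy and hydroxy. Also open is the role of the chain joining the two aromatic rings, as compound 1 differs from the others in more than one place and a longer chain, or one without the double bond, has no single-change pair among the compounds shown.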